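Ring in place of chain on the amide nitrogen

This account rests on a few compounds, and the source may have more. Where it says the series, first, only, none or still open, it means among the compounds named here.

Three measured compounds share one core and differ only in the group on the amide nitrogen. Compound 1 `CCCCNC(=O)[C@H]1OC(n2cnc3c(N)ncnc32)[C@H](O)[C@@H]1O` gives 17 nM in an assay on cell membranes for binding affinity to 2-oxoglutarate receptor 1 (Rattus norvegicus), read by radioligand binding; on this read-out higher numbers stand for weaker inhibition and lower numbers for stronger inhibition. Compound 2 `CCCCCNC(=O)[C@H]1O[C@@H](n2cnc3c(N)ncnc32)[C@H](O)[C@@H]1O` gives 12 nM. Compound 3 `CCCCCCCNC(=O)[C@H]1OC(n2cnc3c(N)ncnc32)[C@H](O)[C@@H]1O` gives 20 nM. Compound 2 has the lowest of these three numbers, yet its gaps to compound 1 and compound 3 both lie within the scatter, so no order among them can be claimed. For the measured compounds named here, the one single-point step available, a 1.2-fold higher number from compound 1 to compound 3 (0.07 log units; within the scatter), lengthens the chain and stays within the scatter.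

Compound 4 `C[C@H]1CC[C@H](NC(=O)[C@H]2O[C@@H](n3cnc4c(N)ncnc43)[C@H](O)[C@@H]2O)CC1` carries a different change: 4-methylcyclohexyl in place of pentyl on an amide-type nitrogen. Going by the values given here, no measured step swaps a chain for a ring, so only the chain-length step bears on it, and that step showed no effect. As far as these compounds go, the expectation is therefore no step beyond the scatter, a 1.3-fold higher number from compound 2 to compound 4 (0.10 log units; within the scatter), with wide uncertainty since the ring is untested. Compound 4 is estimated at 15 nM, in the range 5 nM to 50 nM.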

Compound 4, inhibition constant: 12.9 nM
Beside the measured number, compound 4's estimate is 1.2-fold (0.07 log units) above it; the range from low to high includes it.
By their numbers in this assay, from the lowest: compounds 2, 4, 1 and 3 (each within the scatter of the next).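

For the compounds shown here, compound 4 puts a ring on the amide nitrogen, where the earlier compounds carried only open chains. In this assay, 4-methylcyclohexyl in place of pentyl gives a 1.1-fold higher number from compound 2 to compound 4 (0.03 log units; within the scatter) and so stays within the scatter. This position therefore takes a six-membered non-aromatic ring of carbon only, with 7 heavy atoms instead of 5, without a measurable shift in the read-out, and no evidence is available on why the ring and the chain read alike.

Still open, as far as these compounds go, is whether a plain cyclohexyl without the methyl, or the other stereoisomer of 4-methylcyclohexyl, would read the same. Also open, from the compounds shown here alone, is whether a phenyl ring, or a chain ending in an amine or a carboxylic acid, would stay within the scatter on this nitrogen.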